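The compounds below may be only part of what the source reports. "The series", "measured", "known", "first", "only" and "open" are said of these compounds alone.

Compound 1 `Nc1ccccc1NC(=O)c1ccc(CSC(=S)N2CCc3cc([N+](=O)[O-])ccc32)cc1`: 26.8%
Compound 2 `CC1CCCCN1C(=S)SCc1ccc(C(=O)Nc2ccccc2N)cc1`: 64.4%
Compound 3 `Nc1ccccc1NC(=O)c1ccc(CSC(=S)N2CCN(Cc3ccccc3)CC2)cc1`: 18.1%

In a functional assay on MGC-803 cells (Homo sapiens) for antiproliferative activity, read by CCK-8 assay, with a stated time of 72 h, tested at 2 uM (a lower number here means a weaker effect, a higher number a stronger effect of the compound at the concentration tested), compound 2 gives the highest of the three numbers; compound 1 sits lower by a margin beyond the scatter, and compound 3 lower still, also beyond the scatter. Compound 4 `CN(C(=S)SCc1ccc(C(=O)Nc2ccccc2N)cc1)c1cccnc1` has not yet been measured. It differs from compound 2 in one place: methyl(pyridin-3-yl)amino in place of 2-methylpiperidin-1-yl on a thiocarbonyl carbon. Among the measured compounds shown here, no pair of measured compounds shares this change, so there is no direct guide to its size. Both other measured compounds, each carrying a different group on the thiocarbonyl carbon, fall well short of compound 2, so the step of a number 29.4 percentage points lower from compound 2 to compound 4 (beyond the scatter) is expected to be downward and beyond the scatter. Compound 4 is estimated at 35%, within a range from 15% to 58%.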

Compound 4, a percentage reported as inhibition, at one concentration (the size of the read-out at that concentration, not a potency): 46.1%
Estimate against measurement, compound 4: 11.1 percentage points below; measured number inside the range.
By their numbers in this assay, from the lowest: compounds 3 and 1 (each within the scatter of the next); then compound 4; then compound 2.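

In this assay, putting methyl(pyridin-3-yl)amino in place of 2-methylpiperidin-1-yl on the thiocarbonyl carbon gives a number 18.3 percentage points lower from compound 2 to compound 4 (beyond the scatter), the only direct measure of a change at this position. The aromatic ring costs part of the effect but not all of it, since compound 4 still gives 46.1% at the concentration tested. Nothing measured here explains the drop. The compounds shown leave open which part of the change carries the step, since neither a plain piperidin-1-yl nor a methyl(phenyl)amino group appears among them.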